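Hydroxymethyl on the thiazole of compound 3: solubility

The source may hold more compounds than are shown below. What is called first, only, known or untested is meant among the compounds shown, and "the series" means these compounds.

Compound 1 `CC(C)c1ncc2c(N)c(C#N)c(N)nc2n1`: in a physicochemical assay for solubility, in phosphate buffer, with a stated time of 18 h (a higher number here means a more soluble compound, a lower number a less soluble compound), compound 1 gives a value at the limit > 1000000 nM.
Compound 2 `N#Cc1c(N)nc2nc(C3CC3)ncc2c1N`: in this assay compound 2 gives 23000 nM.
Compound 3 `CC(C)(C)c1nc(-c2nccs2)c2c(N)c(C#N)c(N)nc2n1`: in this assay compound 3 gives a value at the limit < 1500 nM.

Compound 3 stands at the lower limit of the assay, with no number behind it; this is the limit of < 1500 nM in this assay, at which 1 of the 3 values shown sits. Compound 1 sits at the other end, at the limit of > 1000000 nM in this assay, at which 1 of the 3 values shown sits, so the series spans the whole measurable range. For the measured compounds named here, the only step between measured compounds is an at least 43-fold lower number from compound 1 to compound 2 (1.63 log units; beyond the scatter), a change on the shared core and not on the thiazole, so it does not bear directly on the step now in question.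

Compound 4 `CC(C)(C)c1nc(-c2nc(CO)cs2)c2c(N)c(C#N)c(N)nc2n1` differs from compound 3 by hydroxymethyl in place of hydrogen on an aromatic carbon. Going by the values given here, no measured step in this set tests this kind of change, so the expectation rests only on where compound 3 stands. Compound 4 is expected to move upward from the limit by about an at least 2.0-fold higher number from compound 3 to compound 4 (0.30 log units; that floor lies within the scatter). The estimate for compound 4 is 3000 nM, with a likely range from 1000 nM to 15000 nM.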

Compound 4, solubility: < 1000 nM
Compound 4 gave a limit, no number (the forecaster's own chance of this, stated with the estimate: 30%); middle value at least 3.0-fold (0.47 log units) from the limit.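

In this assay compound 3 gives < 1500 nM, which is a limit. Compound 4 gives < 1000 nM, also a limit, so the step between these two compounds cannot be read. As far as these compounds go, whether hydroxymethyl in place of hydrogen on the thiazole raises or lowers the number remains open.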